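The source may report more compounds than this note shows. Statements on the series, on what has been measured and on what is new or still open speak of the compounds shown alone.

Working notes on the series. Of the compounds shown here, three have been measured: compound 1 `CN1CCN(c2nc(-c3ccc(Cl)c(Cl)c3)nc3[nH]cnc23)CC1`, compound 2 `CN1CCN(c2nc(-c3cccc(Cl)c3)nc3c2ncn3C)CC1` and compound 3 `Cn1cnc2c(N3CCCCC3)nc(-c3cccc(Cl)c3)nc21`. In an assay on cells for displacement of a labelled ligand from adenosine receptor A1 (Homo sapiens), read by scintillation counting and radioligand binding, with a stated time of 60 min, tested at 10 uM (on this read-out higher numbers stand for more inhibition at the one concentration tested (going by the name of the read-out) and lower numbers for less inhibition), compound 2 gives 45.7%, the higher of the two plain numbers. Within the data shown here, compound 3 gives 22.4% in this assay, and the step of a number 23.3 percentage points lower from compound 2 to compound 3 (beyond the scatter) is the only single-point change measured so far. The value of compound 1 in this assay, > 80%, is a limit of the assay and not a number (the limit of > 80% in this assay, at which 1 of the 3 values shown sits).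

Compound 4 `CN1CCN(c2nc(-c3ccc(Cl)c(Cl)c3)nc3c2ncn3C)CC1` has not yet been measured in this assay. It differs from compound 2 by chloro in place of hydrogen on an aromatic carbon. Among the measured compounds shown here, no measured step covers this change; the step of a number 23.3 percentage points lower from compound 2 to compound 3 (beyond the scatter) alters a different part of the core and cannot be carried over. What remains is that compound 1, which also carries 3,4-dichlorophenyl, sits at the limit. On that ground a rise beyond the scatter is expected. Compound 4 is estimated at 65%, with a range from 40% to 85%, which is an expected step of a number 19.3 percentage points higher from compound 2 to compound 4 (beyond the scatter).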

Compound 4, a percentage reported as inhibition, at one concentration (the size of the read-out at that concentration, not a potency): 65.2%
The estimate for compound 4 lay 0.2 percentage points below the measured number, within the range that was stated.
By their numbers in this assay, from the lowest: compound 3; then compound 2; then compound 4. At a limit, above all of these: compound 1.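

In this assay, among these compounds, the step of a number 19.5 percentage points higher from compound 2 to compound 4 (beyond the scatter) is the first measured change on this six-membered aromatic ring of carbon only, and it shows 3,4-dichlorophenyl reading above 3-chlorophenyl with the rest of the structure unchanged. The step of a number at least 14.8 percentage points lower from compound 1 to compound 4 (beyond the scatter) is a second single-place change, and it links methyl in place of hydrogen on an aromatic nitrogen to a lower reading among the two 3,4-dichlorophenyl compounds. The reading of compound 1 is a limit and not a number, and the exact size of that step stays unfixed: the limit of > 80% in this assay, at which 1 of the 4 values shown sits.

From the compounds shown here alone, whether chloro at this place raises the reading when piperidin-1-yl replaces 4-methylpiperazin-1-yl stays open. Also open, going by these compounds, is how fluoro, methoxy or an amine at this place would read, and how an ethyl or longer chain on the aromatic nitrogen would read.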